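The source may hold more compounds than are shown below. What is called first, only, known or untested is meant among the compounds shown, and "the series" means these compounds.

Of the compounds shown here, two have been measured in a functional assay on CHO cells with sphingosine 1-phosphate receptor 2 (Homo sapiens) as the target, read by GTPgammaS binding; a lower number here means that less compound is needed, a higher number that more compound is needed for the effect. Within the data shown here, compound 1, with the structure `Cc1ccccc1-c1noc(-c2ccc(C3CCCCC3)cc2)n1`, is the first. In this assay compound 1 gives only a limit, > 10000 nM, and no number. Compound 2, with the structure `Cc1cc(CCC(=O)O)ccc1-c1noc(-c2ccc(OC(C)C)c(C(F)(F)F)c2)n1`, is the second. In this assay compound 2 likewise gives only a limit, > 10000 nM, and no number. On the numbers shown, compound 2 therefore stands at the same place as compound 1: both sit at the limit of > 10000 nM in this assay, at which 2 of the 2 values shown sit, so neither shows a measurable effect within the range the assay covers, and no distance between them can be read.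

Compound 3, with the structure `COc1ccc(-c2nc(-c3ccc(CCC(=O)O)cc3C)no2)cc1C(F)(F)F`, has not yet been measured. It differs from compound 2 in a single place: methyl in place of isopropyl on an oxygen on an aromatic ring, which, cut one bond further out, reads isopropoxy to methoxy. Among the measured compounds shown here, no pair of measured compounds shows what such a change does in this assay. Because compound 2 sits at the limit of > 10000 nM in this assay, at which 2 of the 2 values shown sit, the step is expected to be none beyond the scatter, and compound 3 is expected to return a limit once more a step that the limit leaves unreadable from compound 2 to compound 3. Compound 3 is expected to give about 15000 nM, within a range from 4000 nM to 60000 nM.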

Compound 3, half-maximal effective concentration: > 10000 nM
Compound 3 ended at the assay's limit; the forecaster's own chance of this, stated with the estimate: 85%; the middle value is on the limit's open side.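

Compound 2 and compound 3 both end at a limit rather than a number, so the size of the change from isopropoxy to methoxy cannot be read: the limit of > 10000 nM in this assay, at which 3 of the 3 values shown sit.

The compounds shown leave open where the true values lie and what kind of structure, if any, would give a measurable number in this assay.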